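The source may hold more compounds than are shown below. What is called first, only, known or untested is meant among the compounds shown, and "the series" means these compounds.

Among the compounds with values here, in a functional assay on U-87MG ATCC cells for antiproliferative activity against U-87 MG (Homo sapiens), read by sulforhodamine B assay, with a stated time of 72 h (on this read-out higher numbers stand for weaker inhibition and lower numbers for stronger inhibition), only two compounds have numbers so far. Compound 1 `COc1cc(/C=C/COC(C)=O)ccc1OC(C)=O` gives 1060 nM and stands lowest of the two, which means the stronger inhibition. Compound 2 `CCC(=O)OC/C=C/c1ccc(OC(=O)CC)c(OC)c1` gives 28800 nM and the gap between them lies beyond the usual scatter. Compound 3 `CCCC(=O)Oc1ccc(/C=C/COC(C)=O)cc1OC` has not yet been measured. It differs from compound 1 in one place, a saturated chain carbon bound to a carbonyl carbon, where ethyl stands in place of hydrogen (ethyl in place of hydrogen on a saturated chain carbon bound to a carbonyl carbon) and so turns acetoxy into (propylcarbonyl)oxy. Within the data shown here, no measured pair shows this change on its own, which leaves the step uncertain. Among the measured compounds shown here, compound 2 at 28800 nM is the only comparison available, and it points toward a higher number. The estimate is a moderate step of a 3.8-fold higher number from compound 1 to compound 3 (0.58 log units; beyond the scatter) toward weaker inhibition. Compound 3 is estimated at 4000 nM with a range from 1000 nM to 20000 nM expected.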

Compound 3, half-maximal inhibitory concentration: 10500 nM
Compound 3: middle estimate off by 2.6-fold (0.42 log units), on the low side, within the range that was stated.
By their numbers in this assay, from the lowest: compound 1; then compound 3; then compound 2.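

In this assay the change from acetoxy to (propylcarbonyl)oxy can now be read on its own, and it gives a 9.9-fold higher number from compound 1 to compound 3 (1.00 log units; beyond the scatter) toward weaker inhibition. This saturated chain carbon bound to a carbonyl carbon therefore does not take ethyl in place of hydrogen without a loss, and an addition of only 2 heavy atoms already carries the number beyond the usual scatter. Nothing available here explains this loss.

A single step cannot show whether the loss grows steadily with chain length, so a methyl group at this place, or a longer chain such as butyl, would be needed to tell. It also leaves open how a group of another kind, such as an amine or a carboxylic acid, would behave here.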